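The source may report more compounds than this note shows. Statements on the series, on what has been measured and on what is new or still open speak of the compounds shown alone.

In a functional assay on HCT-116 cells (Homo sapiens) for cytotoxicity, read by scintillation counting and thymidine incorporation, with a stated time of 72 h (a lower number here means a stronger inhibitor, a higher number a weaker inhibitor), compound 1 `CCOc1cc(C(=CC#N)c2ccc(OC)c(F)c2)ccc1OC` gives 130 nM and stands at the high end of the three numbers that have been recorded. Compound 2 `COc1cc(OC)cc(/C(=C/C#N)c2ccc(OC)c(OC)c2)c1` gives 110 nM in this assay, a value within the scatter of compound 1, while compound 3 `CC=C(c1cc(OC)cc(OC)c1)c1ccc(OC)c(O)c1` gives 30 nM, a gap that lies beyond the scatter. Compound 4 `CCOc1cc(C(=CC#N)c2ccc(OC)c(OC)c2)ccc1OC` has not yet been run in this assay. Relative to compound 1, the counted difference is methoxy in place of fluoro on an aromatic carbon. Going by the values given here, no step between measured compounds isolates this exchange, so the guide is weak. The expected step of a 1.3-fold lower number from compound 1 to compound 4 (0.11 log units; within the scatter) in this assay is small and toward a lower number, within the scatter. Compound 4 is thus estimated at 100 nM, with a range of 40 nM to 250 nM.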

Compound 4, half-maximal inhibitory concentration: 200 nM
Estimate against measurement, compound 4: 2.0-fold (0.30 log units) below; the measured number falls inside the stated range.
By their numbers in this assay, from the lowest: compound 3; then compounds 2, 1 and 4 (each within the scatter of the next).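

In this assay, methoxy in place of fluoro on an aromatic carbon, ortho to a methoxy group, gives a 1.5-fold higher number from compound 1 to compound 4 (0.19 log units; within the scatter). Going by these compounds alone, this is the first direct reading of this exchange, and it shows that the fluoro and methoxy groups cannot be told apart at this position in this assay. Nothing available accounts for this result.

On these data alone, whether an amine or a longer chain such as propoxy would also fall within the scatter at this position remains open. So does whether the exchange would give a similar step on a different core.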